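Compound 3 and Its Extended Chain Ahead of Measurement

This account rests on a few compounds, and the source may have more. Where it says the series, first, only, none or still open, it means among the compounds named here.

compound 1 (`NCCCCN(C[C@H]1Cc2cccnc2CN1)[C@H]1CCCc2cccnc21`) gives 2 nm/s
compound 2 (`NCCCCN(C[C@@H]1Cc2cccnc2CN1)[C@H]1CCCc2cccnc21`) gives "not determined" (no result reported)
compound 3 (`NC/C=C\CN(C[C@H]1Cc2ncccc2CN1)[C@H]1CCCc2cccnc21`) gives 28 nm/s

In an ADME assay for permeability, using PAMPA, with a stated time of 4 h, at pH 5.5 (on this read-out higher numbers stand for higher permeability and lower numbers for lower permeability), compound 3 at 28 nm/s holds the higher of the two numbers, with compound 1 at 2 nm/s lower by a gap beyond the scatter. Compound 2 offers no number to compare. Compound 4 (`NC(=O)NC/C=C/CN(C[C@H]1Cc2ncccc2CN1)[C@H]1CCCc2cccnc21`) awaits measurement, and its change from compound 3 is a group of 7 heavy atoms (4 carbon, 2 nitrogen, 1 oxygen; no ring) in place of a group of 4 heavy atoms (3 carbon, 1 nitrogen; no ring), on a saturated chain carbon bound to an amine nitrogen in the words of the count. For the measured compounds named here, no measured pair shows what such a change does, so no step beyond the scatter is expected in either direction. The estimate amounts to a 1.1-fold lower number from compound 3 to compound 4 (0.05 log units; within the scatter) as the expected step. Compound 4 is expected in this assay at 25 nm/s with an estimated range from 6 nm/s to 100 nm/s overall.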

Compound 4, apparent permeability: 6 nm/s
Compound 4: the middle estimate sits 4.2-fold (0.62 log units) above what was measured; the measured number falls inside the stated range.
By their numbers in this assay, from the lowest: compound 1; then compound 4; then compound 3.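

In this assay, for the compounds shown here, the first step that can be read at this place, on a saturated chain carbon bound to an amine nitrogen, is a 4.7-fold lower number from compound 3 to compound 4 (0.67 log units; beyond the scatter) and shows that the number responds to a change there. It comes with a group of 7 heavy atoms taking the place of 3-aminoprop-1-en-1-yl. Nothing at hand bears on why the number moves. From the compounds shown here alone, whether an acetamide or a longer chain at this place would move the number the same way stays open, as does the same change on the core of compound 1.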